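Carbonyl substituent change from compound 3 to compound 4

The source may report more compounds than this note shows. Statements on the series, on what has been measured and on what is new or still open speak of the compounds shown alone.

Compound 3 `CC(C)(C)c1nc(NC(N)=O)ncc1-c1ccccc1` holds the lowest of the three numbers in a functional assay on the whole organism for inhibition, with Rattus norvegicus as the target, with stated times of 1 h and 3.5 h, at a dose of 100 mg/kg by the oral route; a lower number here means less inhibition, a higher number more inhibition at the dose given (going by the name of the read-out); compound 3 gives 14%. Its nearest neighbour is compound 2 `CCOC(=O)Nc1ncc(-c2ccccc2)c(C(C)(C)C)n1`, for which compound 2 gives 24%, and the two lie within the scatter. The furthest is compound 1 `CC(C)(C)c1ncncc1-c1ccccc1`, the unsubstituted parent, where compound 1 gives 48%, a gap beyond the scatter. Both substituents entering on an aromatic carbon lowered the number: a number 24 percentage points lower from compound 1 to compound 2 (beyond the scatter) and a number 34 percentage points lower from compound 1 to compound 3 (beyond the scatter).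

Compound 4 `CC(C)(C)c1nc(NC(=O)CCCC(=O)O)ncc1-c1ccccc1` is not yet measured and differs from compound 3 in one place: 3-carboxypropyl in place of amino on a carbonyl carbon. The step that bears directly on this is the other exchange on the carbonyl carbon, a number 10 percentage points lower from compound 2 to compound 3 (within the scatter), which stayed within the scatter. The changes that moved the number beyond the scatter both involved the aromatic carbon, which is untouched here, and compound 3 already sits at the low end. The expectation is therefore a step of no size beyond the scatter, and the estimated step is a number 1 percentage points higher from compound 3 to compound 4 (within the scatter). Compound 4 is expected to give 15%, with a range from 0% to 35%.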

Compound 4, a percentage reported as inhibition, in the whole organism at one dose (the size of the read-out at that dose, not a potency): 5%
Beside the measured number, compound 4's estimate is 10 percentage points above it, and the stated range covers the measured number.
By their numbers in this assay, from the lowest: compounds 4, 3 and 2 (each within the scatter of the next, the first and the last beyond it); then compound 1.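

On the carbonyl carbon, the exchange of amino for the much larger 3-carboxypropyl in this assay gives a number 9 percentage points lower from compound 3 to compound 4 (within the scatter), so a chain ending in a carboxylic acid can enter here without a step beyond the scatter. Among the compounds shown here, measured against the ethoxy group, the same chain gives a number 19 percentage points lower from compound 2 to compound 4 (beyond the scatter), the first exchange at this carbonyl carbon to pass the scatter, since the step from ethoxy to amino did not; the three substituents thus separate only at their two ends, ethoxy and 3-carboxypropyl. Nothing available accounts for either step, and the data give no reason for the separation between these two groups.

Still open, from the compounds shown here alone, is which part of the 3-carboxypropyl group matters at this position: the chain or its terminal carboxylic acid. An ethyl ester of that acid, a terminal amine on the same chain, or a shorter or longer chain would help to separate the two, and a single-dose read-out leaves potency itself undefined.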